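Removing a Methyl Group from an Aryl Ether Agonist

This account rests on a few compounds, and the source may have more. Where it says the series, first, only, none or still open, it means among the compounds named here.

Three compounds were measured in an assay on HEK293-A cells for agonist activity at probable G-protein coupled receptor 34 (Mus musculus), with a stated time of 1.5 h; a lower number here means a smaller maximal response, a higher number a larger maximal response. Compound 2 `Cc1ccc(Oc2cccc(COc3ccccc3CCC(=O)O[C@@H]3CCCO[C@@H]3COP(=O)(O)OC[C@H](N)C(=O)O)c2)cc1` and compound 3 `Cc1ccc(Oc2cccc(COc3ccccc3CCC(=O)OC[C@H]3OCCC[C@H]3OP(=O)(O)OC[C@H](N)C(=O)O)c2)cc1` share the same atoms joined differently; the difference between the two cores is not broken down here. In this assay compound 2 gives 16% and compound 3 gives 15.2%. Compound 1 `N[C@@H](COP(=O)(O)O[C@@H]1CCCO[C@@H]1COC(=O)CCc1ccccc1OCc1cccc(Oc2ccccc2)c1)C(=O)O` differs from compound 3 by hydrogen in place of methyl on an aromatic carbon, and in this assay compound 1 gives 14.8%, a step of a number 0.4 percentage points lower from compound 3 to compound 1 (within the scatter). Compound 4 `N[C@@H](COP(=O)(O)OC[C@H]1OCCC[C@H]1OC(=O)CCc1ccccc1OCc1cccc(Oc2ccccc2)c1)C(=O)O`, not yet measured, differs from compound 2 by hydrogen in place of methyl on an aromatic carbon, the same change at the same kind of place. Because the step of a number 0.4 percentage points lower from compound 3 to compound 1 (within the scatter) stayed within the scatter, the expected step from compound 2 to compound 4 is a number 0.4 percentage points lower from compound 2 to compound 4 (within the scatter). Compound 4 is therefore estimated at 15.6%, likely between 9% and 22%.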

Compound 4, largest response reached (Emax), in percent of the reference or control that the assay uses: 17.7%
Compound 4: the middle estimate sits 2.1 percentage points below what was measured, within the range that was stated.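

Going from 4-methylphenoxy to phenoxy in this assay gives a step of a number 1.7 percentage points higher from compound 2 to compound 4 (within the scatter). Set beside the earlier step, the change looks alike on the two cores: the same change on two cores in this assay, a number 0.4 percentage points lower (within the scatter) from compound 3 to compound 1 and a number 1.7 percentage points higher (within the scatter) from compound 2 to compound 4, 2.1 percentage points apart, within the scatter of two such steps. This shows that swapping the methyl for hydrogen leaves the maximal response unchanged within the scatter on both cores, but it does not show that the two steps are truly equal, as a small real difference could stay hidden, or that the same would hold on any other core.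

The compounds shown leave open what other groups on that aromatic carbon would do, such as chlorine, methoxy or ethyl. On these data alone, an amide in place of the ester also remains open.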